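Swapping the cyclohexyl arm for a chlorinated phenyl ring

A few compounds are considered here, and "the series" means these few. Any claim that something is new, unique, unknown or untested is made for them only; others in the source may bear on it.

Compound 1 `COc1nc(C2CCCCC2)ccc1[C@@H](c1ccccc1)[C@@](O)(CCN(C)C)c1cccc2ccccc12` gives 32.3 ug/mL in a toxicity assay on Vero cells (Chlorocebus sabaeus) for cytotoxicity; on this read-out lower numbers stand for higher toxicity in this test and higher numbers for lower toxicity in this test.
Compound 2 `COc1ccc(-c2ccc([C@@H](c3ccccc3)[C@@](O)(CCN(C)C)c3cccc4ccccc34)c(OC)n2)cc1` gives > 50 ug/mL in this assay; this is a limit of the assay, not a number.
Compound 3 `COc1ncc(-c2ccccc2)cc1[C@@H](c1ccccc1)[C@@](O)(CCN(C)C)c1cccc2ccccc12` gives > 50 ug/mL in this assay; this too is a limit of the assay.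

Among the compounds with values here, compound 1 holds the only actual number among the three, since the other two rest at the limit of > 50 ug/mL in this assay, at which 2 of the 3 values shown sit. Compound 4 `COc1nc(-c2ccccc2Cl)ccc1[C@@H](c1ccccc1)[C@@](O)(CCN(C)C)c1cccc2ccccc12` changes compound 1 in one place: 2-chlorophenyl in place of cyclohexyl on an aromatic carbon. Within the data shown here, the one measured step that bears on this, an at least 1.5-fold higher number from compound 1 to compound 2 (0.18 log units; that floor lies within the scatter), also put an aromatic ring in place of cyclohexyl and moved the read-out upward to the limit. For compound 4 a similar outcome is expected, so the estimate is 45 ug/mL, with a plausible range from 20 ug/mL to 100 ug/mL. That estimate means a step of a 1.4-fold higher number from compound 1 to compound 4 (0.14 log units; within the scatter), which is expected to be small or hidden by the limit.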

Compound 4, half-maximal cytotoxic concentration: > 50 ug/mL
Compound 4: no number, only a limit; the forecaster's own chance of this, stated with the estimate: 45%; middle value at least 1.1-fold (0.04 log units) from the limit.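

In this assay a second aromatic ring at this place, now the chlorine-bearing 2-chlorophenyl, gives an at least 1.5-fold higher number from compound 1 to compound 4 (0.18 log units; that floor lies within the scatter) and so shows no change that can be told from scatter. Compound 4 gives > 50 ug/mL here and that is a limit of the assay, not a number. The step between compound 2 and compound 4 cannot be read, so 2-chlorophenyl and 4-methoxyphenyl are not separated, and the set now gathers at one ceiling: the limit of > 50 ug/mL in this assay, at which 3 of the 4 values shown sit.

From the compounds shown here alone, how far these compounds lie past that limit stays open. So does whether an amine or a longer alkyl chain at this place would stay at the limit.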